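The compounds below may be only part of what the source reports. "The series", "measured", "known", "first", "only" and "open" are said of these compounds alone.

Measured so far:
compound 1 `CCCCC#Cc1ccc(S(=O)(=O)Nc2cccc(-c3csc(NC(C)=O)n3)c2)cc1` gives 9.3%
compound 2 `CCCCCCCCC#Cc1ccc(S(=O)(=O)Nc2cccc(-c3csc(NC(C)=O)n3)c2)cc1` gives 8.9%

Both numbers come from a functional assay on A-375 cells (Homo sapiens) for antiproliferative activity, read by trypan blue exclusion, with a stated time of 48 h, tested at 5 uM; a higher number here means a weaker effect of the compound at the concentration tested, a lower number a stronger effect. Compound 1 and compound 2 lie within the scatter of each other, so neither stands apart on the numbers shown; both read as strong effects at the concentration tested. Among the measured compounds shown here, the only measured step, a number 0.4 percentage points lower from compound 1 to compound 2 (within the scatter), shows that lengthening the chain made no difference that can be told from noise.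

Compound 3 `CCCCCC/C=C\c1ccc(S(=O)(=O)Nc2cccc(-c3csc(NC(C)=O)n3)c2)cc1` is the next compound. It differs from compound 2 at one place: a group of 8 heavy atoms (8 carbon; no ring) in place of a group of 10 heavy atoms (10 carbon; no ring), on an aromatic carbon. Two things change at once here, the chain becomes shorter and the triple bond gives way to a double bond. For the measured compounds named here, the step from compound 1 to compound 2 bears on the length part and was within the scatter; no measured step bears on the triple-to-double change. With both measured numbers so close and so low, the expectation is that compound 3 gives a number of similar size, a number 2.1 percentage points higher from compound 2 to compound 3 (within the scatter). Compound 3 is therefore estimated at 11%, within a range from 4% to 24%.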

Compound 3, a percentage reported as activity, at one concentration (the size of the read-out at that concentration, not a potency): 2.3%
For compound 3 the middle estimate is 8.7 percentage points above the measured one; the measured number lies below the stated range.
By their numbers in this assay, from the lowest: compounds 3, 2 and 1 (each within the scatter of the next).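

On this aromatic carbon, para to a large group, the dec-1-yn-1-yl group can be replaced by a chain of 8 carbons that carries a double bond instead of a triple bond without leaving the scatter of this assay: the result is a number 6.6 percentage points lower from compound 2 to compound 3 (within the scatter). The comparison with the shorter chain gives the same reading, a number 7 percentage points lower from compound 1 to compound 3 (within the scatter), so among these three compounds a triple bond is not needed for a strong effect at the concentration tested. No separate measurement bears on this result, so the data offer no explanation for how closely the three compounds agree.

Chain length and bond type change together in both new steps, and no pair shown has the same chain length with a different bond, so the contribution of each remains unresolved. Also open, as far as these compounds go, is how far this tolerance extends, for example to a fully saturated octyl chain, to a much longer chain, or to a chain ending in an amine or a carboxylic acid, and a single concentration cannot show whether potency differs among compounds that all read this low.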